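From Pyridin-3-yl to 2H-1,2,3-Triazol-2-yl in Compound 4

A few compounds are considered here, and "the series" means these few. Any claim that something is new, unique, unknown or untested is made for them only; others in the source may bear on it.

Three compounds have so far been run in a functional assay on a cell-free system (plasma) with sterol O-acyltransferase, Soat (Rattus norvegicus) as the target; a lower number here means that less compound is needed, a higher number that more compound is needed for the effect. Compound 1 `CN(C)c1ccc(CN(Cc2cccc(-c3cc[nH]n3)c2)C(=O)Nc2c(F)cc(F)cc2F)cc1` is reported in this assay only as a limit, < 0.32 mg/kg, and that limit is the reading noted as the limit of < 0.32 mg/kg in this assay, at which 1 of the 3 values shown sits. Compound 2 `CSc1cc(C)nc(SC)c1NC(=O)N(Cc1ccccc1)Cc1cccc(-c2cc[nH]n2)c1` gives 0.046 mg/kg in this assay. Compound 3 `Cc1cc(C)c(NC(=O)N(Cc2ccc(-c3cccnc3)cc2)C2CCCCCC2)c(C)c1` gives 0.58 mg/kg in this assay, the higher of the two numbers that exist; its gap to compound 2 is well beyond the usual scatter, with compound 2 needing the smaller dose.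

Compound 4 `Cc1cc(C)c(NC(=O)N(Cc2ccc(-n3nccn3)cc2)C2CCCCCC2)c(C)c1` is the compound still to be measured. It differs from compound 3 in a single group: 2H-1,2,3-triazol-2-yl in place of pyridin-3-yl on an aromatic carbon. For the measured compounds named here, no pair of measured compounds here differs in just one place, so there is no measured step of comparable kind to lean on. The exchange keeps the same aromatic carbon occupied and swaps one aromatic ring for another, so the step from compound 3 to compound 4 is expected to be modest, and the expectation is for no change beyond the scatter: a 1.2-fold lower number from compound 3 to compound 4 (0.06 log units; within the scatter). Compound 4 is therefore expected to give about 0.5 mg/kg in this assay, with a plausible range from 0.15 mg/kg to 1.6 mg/kg.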

Compound 4, dose for half-maximal effect: > 1 mg/kg
Compound 4: a limit, no number (the forecaster's own chance of this, stated with the estimate: 10%); middle value at least 2.0-fold (0.30 log units) from the limit.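

In this assay, compound 4 carries 2H-1,2,3-triazol-2-yl in place of pyridin-3-yl on the aromatic carbon para to a large group, and its result is a limit rather than an exact number: the limit of > 1 mg/kg in this assay, at which 1 of the 4 values shown sits. For the compounds shown here, this gives the first comparison here between two compounds that differ in only one place, and it reads an at least 1.7-fold higher number from compound 3 to compound 4 (0.23 log units; that floor lies within the scatter), so the true gap could be small or much larger. What it adds is that, at this place, the five-membered aromatic ring with three hetero atoms brings no gain in this assay over the six-membered aromatic ring with one hetero atom.

This single step cannot separate the differences between the two groups, such as ring size, number of hetero atoms and number of hydrogen-bond acceptors, so it does not show which of them, if any, matters. Also open, from the compounds shown here alone, is how the same place would respond to a group of another kind, such as a morpholine ring or a carboxylic acid, and how far the number for compound 4 lies past its limit.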